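Methyl Added Ortho to Benzyloxy on the Coumarin Amide Core

This account rests on a few compounds, and the source may have more. Where it says the series, first, only, none or still open, it means among the compounds named here.

Measured so far:
Compound 1, `COc1ccc(NC(=O)c2cc3ccccc3oc2=O)cc1OC`: 860 nM
Compound 2, `COc1ccc(NC(=O)c2cc3ccc(OCc4ccccc4)cc3oc2=O)cc1OC`: 4390 nM

Of the compounds shown here, two have been measured in an in vitro assay on BTI-TN-5B1-4 cells for inhibition of Amine oxidase [flavin-containing] B (Homo sapiens), read by fluorescence; on this read-out higher numbers stand for weaker inhibition and lower numbers for stronger inhibition. Compound 1 gives 860 nM, and compound 2 gives 4390 nM. For the measured compounds named here, the one measured step, a 5.1-fold higher number from compound 1 to compound 2 (0.71 log units; beyond the scatter), places compound 2 at the higher of the two numbers, with compound 1 standing at the lower one.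

The next compound, compound 3, is `COc1ccc(NC(=O)c2cc3ccc(OCc4ccccc4)c(C)c3oc2=O)cc1OC`. It differs from compound 2 in one place: methyl in place of hydrogen on an aromatic carbon, on an aromatic carbon of a six-membered aromatic ring of carbon only, part of a fused system of two rings, ortho to the benzyloxy group and ortho to a fused ring. Going by the values given here, no measured step in this assay concerns a methyl for hydrogen exchange; the only step available, a 5.1-fold higher number from compound 1 to compound 2 (0.71 log units; beyond the scatter), concerns the benzyloxy group itself and so speaks only indirectly to the present change. With a single heavy atom entering and no donor or acceptor added, the step is expected to be small. Compound 3 is therefore estimated to give 4000 nM in this assay, in the range 1500 nM to 12000 nM, an expected step of a 1.1-fold lower number from compound 2 to compound 3 (0.04 log units; within the scatter).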

Compound 3, half-maximal inhibitory concentration: 4980 nM
For compound 3 the middle estimate is 1.2-fold (0.10 log units) below the measured one; the measured number falls inside the stated range.
By their numbers in this assay, from the lowest: compound 1; then compounds 2 and 3 (each within the scatter of the next).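

In this assay, methyl in place of hydrogen on an aromatic carbon, ortho to the benzyloxy group and ortho to a fused ring, amounts to a 1.1-fold higher number from compound 2 to compound 3 (0.05 log units; within the scatter), so compound 2 and compound 3 cannot be told apart on this read-out. The earlier pair had shown only that the benzyloxy group itself registers, through a 5.1-fold higher number from compound 1 to compound 2 (0.71 log units; beyond the scatter), and had said nothing about this carbon; the new pair shows that it can carry a methyl with no readable consequence for the inhibition measured here. No independent measurement is available to explain this result.

The compounds shown leave open whether this carbon would accept other groups equally well, such as an ethyl group, a methoxy group, a chlorine atom or an amine, since methyl is the only replacement for hydrogen shown there. They also leave open whether methyl at this place would read the same way on the core of compound 1, which has hydrogen where compound 2 has benzyloxy, or alongside a shorter ether such as methoxy.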